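Working notes: cytotoxicity across compounds 1 to 4

The source may report more compounds than this note shows. Statements on the series, on what has been measured and on what is new or still open speak of the compounds shown alone.

Measured so far:
compound 1 `COc1ccc(-c2cs/c(=N/NC(=O)CSc3nnnn3-c3ccccc3)n2-c2ccccc2)cc1`, 11.7 ug/mL
compound 2 `Cn1nnnc1SCC(=O)N/N=c1/scc(-c2ccc(F)cc2)n1-c1ccccc1`, 113 ug/mL
compound 3 `O=C(CSc1ncccn1)N/N=c1/scc(-c2ccc([N+](=O)[O-])cc2)n1-c1ccccc1`, 193 ug/mL

All three numbers come from an ADME assay on NIH3T3 cells (Mus musculus) for cytotoxicity, read by MTT assay, with a stated time of 24 h; a lower number here means a stronger inhibitor, a higher number a weaker inhibitor. Compound 1 gives the lowest number of the three. Compound 2 sits nearest, with a number beyond the scatter above compound 1, and compound 3 lies furthest, also beyond the scatter. Among the compounds with values here, compounds 2 and 3 differ from compound 1 in more than one place, so no single step between measured compounds can be drawn; their values only show that compound 1 is the strongest of the three in this assay.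

Compound 4 `O=C(CSc1nnnn1-c1ccccc1)N/N=c1/scc(-c2ccc(Cl)cc2)n1-c1ccccc1` is not yet measured. Against compound 1 the change is chloro in place of methoxy on an aromatic carbon. Within the data shown here, no measured pair shows this change alone, so its effect is open. The expectation is a modest step upward in number, that is a weaker inhibitor than compound 1, since every other variation of the aryl substituent seen here (compounds 2 and 3) gave a higher number; the step from compound 1 to compound 4 is estimated as a 2.6-fold higher number from compound 1 to compound 4 (0.41 log units; beyond the scatter). The estimate for compound 4 in this assay is 30 ug/mL, with a range from 8 ug/mL to 120 ug/mL.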

Compound 4, half-maximal inhibitory concentration: 313 ug/mL
Estimate against measurement, compound 4: 10-fold (1.02 log units) below, and the stated range ends below it.
By their numbers in this assay, from the lowest: compound 1; then compounds 2, 3 and 4 (each within the scatter of the next, the first and the last beyond it).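

In this assay, within the data shown here, the change from 4-methoxyphenyl to 4-chlorophenyl is the first single change that can be read, and it gives a 27-fold higher number from compound 1 to compound 4 (1.43 log units; beyond the scatter). The position, an aromatic carbon para to a large group, is therefore far from silent in this assay: with everything else in compound 1 held fixed, the exchange of methoxy for chloro alone is enough to lose most of the cytotoxicity, so the low number of compound 1 cannot be credited to the shared core alone. Nothing available bears on why this one change has so large an effect.

Still open, as far as these compounds go, is whether the low number is specific to methoxy, or whether an amine, a hydroxyl group or ethoxy on the same carbon would keep it low. Compounds 2 and 3 differ from the others in more than one place, so their steps cannot be read, and the contribution of the group on the sulfur side of the chain remains unseparated from that of the aryl substituent.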